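The compounds below may be only part of what the source reports. "The series", "measured", "known", "first", "only" and "open" are said of these compounds alone.

Measured in a functional assay on DU-145 cells (Homo sapiens) for cytotoxicity, read by MTT assay, with a stated time of 48 h; on this read-out lower numbers stand for stronger inhibition and higher numbers for weaker inhibition:

- compound 1 `COc1ccc(-c2nc3ccccn3c2C(=O)/C=C\Nc2ccc3cc[nH]c3c2)cc1`: 10700 nM
- compound 2 `COc1cc(N/C=C\C(=O)c2c(-c3ccc(Cl)cc3)nc3ccccn23)cc(OC)c1`: 12000 nM
- compound 3 `O=C(/C=C\Nc1ccc2[nH]ccc2c1)c1c(-c2ccc(Cl)cc2)nc2ccccn12`: 1290 nM

Compound 3, at 1290 nM, holds the lowest number of the three, and both other compounds lie well above it, beyond the scatter. The next compound, compound 4 `O=C(/C=C\Nc1ccc2cc[nH]c2c1)c1c(-c2ccc(Cl)cc2)nc2ccccn12`, is an isomer of compound 3, with the same atoms joined differently: 1H-indol-6-yl in place of 1H-indol-5-yl on an amine nitrogen. In words, 1H-indol-6-yl takes the place of 1H-indol-5-yl on an amine nitrogen.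

Among the compounds with values here, only one measured step bears on this place in the molecule: a 9.3-fold lower number from compound 2 to compound 3 (0.97 log units; beyond the scatter). It shows that the group on the amine nitrogen can shift the number by a modest amount, but it is a different exchange. Within the data shown here, no measured pair isolates the move from 1H-indol-5-yl to 1H-indol-6-yl. Compound 1 does carry 1H-indol-6-yl and gives 10700 nM, but it also differs from compound 4 elsewhere, so it offers only a loose hint of a higher number. The expected change is therefore a modest rise, estimated as a 2.3-fold higher number from compound 3 to compound 4 (0.37 log units; beyond the scatter). For compound 4 the estimated value is 3000 nM, with an expected range from 1000 nM to 9000 nM.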

Compound 4, half-maximal inhibitory concentration: 2630 nM
Compound 4: middle estimate off by 1.1-fold (0.06 log units), on the high side, within the range that was stated.
By their numbers in this assay, from the lowest: compound 3; then compound 4; then compounds 1 and 2 (each within the scatter of the next).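

In this assay, within the data shown here, the first direct pair for this exchange gives a 2.0-fold higher number from compound 3 to compound 4 (0.31 log units; beyond the scatter) and so shows that 1H-indol-5-yl and 1H-indol-6-yl on the amine nitrogen are not interchangeable, though the gap is modest. The 1H-indol-6-yl group still improves on 3,5-dimethoxyphenyl with a 4.6-fold lower number from compound 2 to compound 4 (0.66 log units; beyond the scatter) but by less than the 1H-indol-5-yl group does with a 9.3-fold lower number from compound 2 to compound 3 (0.97 log units; beyond the scatter) in the same comparison. With 1H-indol-6-yl held fixed, a 4.1-fold lower number from compound 1 to compound 4 (0.61 log units; beyond the scatter) shows that chloro in place of methoxy on the aromatic carbon also lowers the number, so the high value of compound 1 reflected that second change and not the 1H-indol-6-yl group alone.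

Going by these compounds, it remains open whether the same chloro for methoxy exchange would hold with 1H-indol-5-yl on the amine nitrogen, and whether fluoro or trifluoromethyl in that place would lower the number further. On these data alone, it is also open whether a pyridinyl group on the amine nitrogen would stay near the two indolyl groups or return toward 3,5-dimethoxyphenyl. Nothing given here accounts for the difference between the two indolyl groups.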